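The source may report more compounds than this note shows. Statements on the series, on what has been measured and on what is new or still open speak of the compounds shown alone.

Working notes on the series.

Among the compounds with values here, compound 3 `COC(=O)NC1CCc2ccc(NC(=O)c3cccc(C)c3-c3ccc(C(F)(F)F)cc3)cc2CC1` gives 20 nM in an assay on isolated protein for inhibition of microsomal triglyceride transfer protein large subunit (Homo sapiens) (a lower number here means a stronger inhibitor, a higher number a weaker inhibitor), and stands lowest of the three numbers measured so far. Compound 1 `COC(=O)N[C@@H]1Cc2ccc(NC(=O)c3ccccc3-c3ccc(C(F)(F)F)cc3)cc2C1` gives 110 nM in this assay, the nearest number to compound 3 and one that lies beyond the scatter from it. Compound 2 `Cc1cccc(C(=O)Nc2ccc3c(c2)CC(CNS(C)(=O)=O)C3)c1-c1ccc(C(F)(F)F)cc1` gives 150 nM in this assay, the furthest from compound 3 and also beyond the scatter. Between these pairs no single-point step has been worked out, so only the bare numbers can be compared: both compound 1 and compound 2 carry larger numbers than compound 3, and nothing more is read into that.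

The next compound, compound 4 `COC(=O)NC1CCc2ccc(NC(=O)c3cc(C)cc(C)c3-c3ccc(C(F)(F)F)cc3)cc2CC1`, keeps the whole of compound 3 and differs in one place only: methyl in place of hydrogen on an aromatic carbon. The core, the methyl carbamate, the amide link and the 4-(trifluoromethyl)phenyl group are unchanged.

Within the data shown here, no measured step of this kind is available, so the expectation rests on the size of the change alone: one carbon added to an aromatic ring that already carries a methyl group. For compound 4 the step of a 1.3-fold higher number from compound 3 to compound 4 (0.10 log units; within the scatter) is expected to be small, in either direction, and most likely not beyond the scatter. Compound 4 is therefore estimated at 25 nM in this assay, with a range from 10 nM to 60 nM.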

Compound 4, half-maximal inhibitory concentration: 20 nM
Compound 4: middle estimate off by 1.3-fold (0.10 log units), on the high side; low and high end bracket the measured number.
By their numbers in this assay, from the lowest: compounds 3 and 4 (each within the scatter of the next); then compounds 1 and 2 (each within the scatter of the next).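

Within the data shown here, the added methyl gives no change at the digits printed from compound 3 to compound 4 (within the scatter) in this assay, and this is the first step that changes one place only. It shows that this aromatic carbon, meta to a methyl group and para to a 4-(trifluoromethyl)phenyl group, can carry a methyl in place of hydrogen with the number remaining within the scatter. Compounds 1 and 2 differ from compound 3 in more than one place, so they could not isolate this position, and nothing on hand bears on the reason for this result.

The step covers a single carbon substituent at a single position, so a methoxy group, a chlorine atom, a longer chain, an amine or a carboxylic acid on the same carbon remains an open case in this assay. Also open, going by these compounds, is whether the same methyl would give a comparable step on the core of compound 1 or the core of compound 2, since one step on one core cannot be carried over to the others.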